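Methyl isomers on the ring amide nitrogen

A few compounds are considered here, and "the series" means these few. Any claim that something is new, unique, unknown or untested is made for them only; others in the source may bear on it.

The series comprises compound 1 `O=C1CC(c2nc(-c3cccc(Cl)c3)no2)CN1Cc1ccc(F)cc1`, compound 2 `Cc1cccc(N2CC(c3nc(-c4cccc(Cl)c4)no3)CC2=O)c1` and compound 3 `O=c1sc2ccccc2n1Cc1nc(-c2cccc(Cl)c2)no1`, all tested in an in vitro functional assay on HEK293-A cells for negative allosteric modulation of metabotropic glutamate receptor 5 (Homo sapiens), read by FLIPR and calcium flux; on this read-out higher numbers stand for weaker inhibition and lower numbers for stronger inhibition. Compound 1 gives 3600 nM, compound 2 gives 2300 nM and compound 3 gives 1100 nM. Compound 2 stands second highest of the three numbers: the step of a 1.6-fold lower number from compound 1 to compound 2 (0.19 log units; within the scatter) lies within the scatter, whereas the gap from compound 2 down to compound 3 lies beyond it. Compound 4 `Cc1ccccc1N1CC(c2nc(-c3cccc(Cl)c3)no2)CC1=O` has not yet been measured. It differs from compound 2 in one place: 2-methylphenyl in place of 3-methylphenyl on an amide-type nitrogen in a ring — the two have the same atoms, joined differently. For the measured compounds named here, only one measured step touches the same amide-type nitrogen in the ring, the exchange of the whole substituent in a 1.6-fold lower number from compound 1 to compound 2 (0.19 log units; within the scatter), and that step stayed within the scatter. Nothing measured separates the two methylphenyl isomers from each other. In this assay the step of no change at the digits printed from compound 2 to compound 4 (within the scatter) is therefore expected to stay within the scatter, with no direction favoured. Compound 4 is estimated at 2300 nM, in the range 1000 nM to 5500 nM.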

Compound 4, half-maximal inhibitory concentration: 370 nM
The estimate for compound 4 lay 6.2-fold (0.79 log units) above the measured number; the whole stated range lies above it.
By their numbers in this assay, from the lowest: compound 4; then compound 3; then compounds 2 and 1 (each within the scatter of the next).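

In this assay the substituent on the amide-type nitrogen in the ring responds to the placement of a single methyl group alone (a 6.2-fold lower number from compound 2 to compound 4 (0.79 log units; beyond the scatter)), although 3-methylphenyl and 2-methylphenyl have the same atoms and the same counts of rings, donors and acceptors. Exchanging the whole substituent also gives a step beyond the scatter when 2-methylphenyl enters (a 9.7-fold lower number from compound 1 to compound 4 (0.99 log units; beyond the scatter)), whereas the step to 3-methylphenyl stayed within it (a 1.6-fold lower number from compound 1 to compound 2 (0.19 log units; within the scatter)). Nothing available here bears on the reason for the isomer step.

Open, going by these compounds, is whether 4-methylphenyl, 2-chlorophenyl or 2-methoxyphenyl on the same nitrogen would follow 2-methylphenyl or 3-methylphenyl. Also open, on these data alone, is whether a 2-methylbenzyl group would give a similar step from 4-fluorobenzyl.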